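The source may hold more compounds than are shown below. What is called first, only, known or untested is meant among the compounds shown, and "the series" means these compounds.

Going by the values given here, only two compounds sharing one core have been measured so far, compound 1 `CCn1c([C@@H](C)NS(=O)(=O)c2cn(C)nc2C)nc2ccc(C(F)(F)F)cc21` and compound 2 `CCn1c([C@@H](C)NS(=O)(=O)c2cn(C)c(C)n2)nc2ccc(C(F)(F)F)cc21`. In an ADME assay (liver) for metabolic stability, with Liver microsome (Homo sapiens) as the target, read by LC-MS, using microsomes and NADPH, with a stated time of 5 min, at 37 degrees C (on this read-out lower numbers stand for slow clearance and higher numbers for fast clearance), compound 1 gives 28 mL.min-1.g-1 and compound 2 gives 43 mL.min-1.g-1 on the same scale, which places compound 2 within the usual scatter of compound 1.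

Compound 3 `CCn1c([C@@H](C)NS(=O)(=O)c2cnc(NC(C)=O)s2)nc2ccc(C(F)(F)F)cc21` keeps the core but carries 2-acetamido-1,3-thiazol-5-yl in place of 1,2-dimethyl-1H-imidazol-4-yl on a sulfonyl sulfur. Group by group, 2-acetamido-1,3-thiazol-5-yl in place of 1,2-dimethyl-1H-imidazol-4-yl on a sulfonyl sulfur is the whole difference between the two structures.

Among the compounds with values here, only one measured step bears on this change, a swap on the same sulfonyl sulfur, and it was small: a 1.5-fold higher number from compound 1 to compound 2 (0.19 log units; within the scatter) in that case. That swap exchanged one dimethyl-substituted group for another, so it says little about an acetamido group, and the range must stay wide. In this assay no step beyond the scatter is expected, and no direction is firmly supported. The estimated step is a 1.3-fold lower number from compound 2 to compound 3 (0.13 log units; within the scatter) and should be read as a weak expectation only. For compound 3 the estimated value is 32 mL.min-1.g-1 with an expected range from 13 mL.min-1.g-1 to 75 mL.min-1.g-1 on this read-out.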

Compound 3, intrinsic clearance in microsomes: 15 mL.min-1.g-1
Estimate against measurement, compound 3: 2.1-fold (0.33 log units) above; the measured number falls inside the stated range.
By their numbers in this assay, from the lowest: compounds 3, 1 and 2 (each within the scatter of the next, the first and the last beyond it).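

Going by these compounds alone, at this sulfonyl sulfur, the earlier swap between two dimethyl-substituted groups stayed within the scatter, whereas 2-acetamido-1,3-thiazol-5-yl gives a 2.9-fold lower number from compound 2 to compound 3 (0.46 log units; beyond the scatter) in this assay and so provides the first step at this position that lies beyond it. Measured against 1,3-dimethyl-1H-pyrazol-4-yl, the same group gives a 1.9-fold lower number from compound 1 to compound 3 (0.27 log units; within the scatter) on this read-out, so the clear change holds only against 1,2-dimethyl-1H-imidazol-4-yl, and the new group cannot be called better than both dimethyl groups. No measurement at hand explains why clearance falls with this change.

The thiazole ring and the acetamido group enter together, so the compounds shown do not tell which part accounts for the step; a plain 1,3-thiazol-5-yl, or the same ring carrying a free amine in place of the acetamido group, would begin to separate the two. Also open, going by these compounds, is whether a longer acyl chain on that amide nitrogen, or a carboxylic acid on the ring, would keep clearance as low as in compound 3.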